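The compounds below may be only part of what the source reports. "The series", "measured", "known", "first", "only" and "open" are said of these compounds alone.

Compound 3 `C=CC(=O)Nc1cccc(NC(=O)CSc2nc(Nc3ccccc3C)c3ccccc3n2)c1` in a functional assay on PC-3 cells (Homo sapiens) for inhibition, read by MTT assay, with a stated time of 72 h (on this read-out lower numbers stand for stronger inhibition and higher numbers for weaker inhibition), gives 23200 nM, the highest of the three numbers shown, though within the scatter of compound 1 `O=C(CSc1nc(Nc2ccccc2)c2ccccc2n1)Nc1ccccc1Br`, which gives 19800 nM, and of compound 2 `O=C(CSc1nc(Nc2ccccc2)c2ccccc2n1)Nc1cccc([N+](=O)[O-])c1`, which gives 11800 nM. Among the compounds with values here, the one measured step, a 1.7-fold lower number from compound 1 to compound 2 (0.22 log units; within the scatter), changes the group on an amide-type nitrogen, a different place from the change leading to compound 4 `C=CC(=O)Nc1cccc(NC(=O)CSc2nc(Nc3ccc(Cl)c(Cl)c3)c3ccccc3n2)c1`, which is 3,4-dichlorophenyl in place of 2-methylphenyl on a nitrogen on an aromatic ring. Within the data shown here, no measured step touches this place, so the numbers give no direction for it; a step of no more than the usual scatter is expected, a 1.2-fold lower number from compound 3 to compound 4 (0.06 log units; within the scatter). Compound 4 is therefore estimated at 20000 nM in this assay, with a range from 7000 nM to 60000 nM.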

Compound 4, half-maximal inhibitory concentration: 27600 nM
Compound 4: the middle estimate sits 1.4-fold (0.14 log units) below what was measured, within the range that was stated.
By their numbers in this assay, from the lowest: compounds 2, 1, 3 and 4 (each within the scatter of the next, the first and the last beyond it).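

In this assay, within the data shown here, placing 3,4-dichlorophenyl instead of 2-methylphenyl on the nitrogen gives the first measured step at this position (a 1.2-fold higher number from compound 3 to compound 4 (0.08 log units; within the scatter)). This one pair therefore does not separate the two groups, although they differ in their substituents and the entering group contains two chlorine atoms. No measurement available here bears on this result. As far as these compounds go, it remains open whether an amine or a carboxylic acid on this phenyl ring, or a longer carbon chain in place of the ring, would give a step beyond the scatter.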